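Chalcone-linked series: reversing the enone toward compound 3

The compounds below may be only part of what the source reports. "The series", "measured", "known", "first", "only" and "open" are said of these compounds alone.

Of the compounds shown here, two of the shared core have numbers so far. Compound 1 `COc1ccc(-c2cc(/C=C/C(=O)c3cc(OC)c(OC)c(OC)c3)nc3cc(-c4ccccc4)nn23)cc1OC` carries a trimethoxyphenyl carbonyl at the far end of the ethenyl linker; in a functional assay on DU-145 cells (Homo sapiens) for antiproliferative activity, read by MTT assay, with a stated time of 24 h (a lower number here means a stronger inhibitor, a higher number a weaker inhibitor), compound 1 gives 8300 nM. Compound 2 `COc1ccc(-c2cc(C(=O)/C=C/c3ccc(Cl)cc3)nc3cc(-c4ccccc4)nn23)cc1OC` carries the carbonyl directly on the core with a 4-chlorophenyl on the ethenyl end; in this assay compound 2 gives 22400 nM, the higher of the two numbers, and its gap to compound 1 lies beyond the scatter.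

Compound 3 `COc1ccc(-c2cc(/C=C/C(=O)c3ccc(C)c(C)c3)nc3cc(-c4ccccc4)nn23)cc1OC` is not yet measured. It differs from compound 2 in one place: 2-((3,4-dimethylphenyl)carbonyl)ethenyl in place of (2-(4-chlorophenyl)ethenyl)carbonyl on an aromatic carbon. The orientation of the linker in compound 3 matches that of compound 1, but the aryl group differs from both. The step of a 1.9-fold lower number from compound 2 to compound 3 (0.27 log units; within the scatter) is expected to be a modest move toward a lower number, since compound 1 with the same linker orientation gives 8300 nM. Compound 3 is estimated at 12000 nM, with a range from 4000 nM to 35000 nM.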

Compound 3, half-maximal inhibitory concentration: 12100 nM
The estimate for compound 3 lay 1.0-fold (0.00 log units) below the measured number, within the range that was stated.
By their numbers in this assay, from the lowest: compounds 1, 3 and 2 (each within the scatter of the next, the first and the last beyond it).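

In this assay, 3,4-dimethylphenyl in place of 3,4,5-trimethoxyphenyl on the carbonyl carbon gives a 1.5-fold higher number from compound 1 to compound 3 (0.16 log units; within the scatter), so this aryl change, with the linker orientation held, is not resolved by this read-out. At the aromatic carbon of the shared core, 2-((3,4-dimethylphenyl)carbonyl)ethenyl in place of (2-(4-chlorophenyl)ethenyl)carbonyl gives a 1.9-fold lower number from compound 2 to compound 3 (0.27 log units; within the scatter), so this larger replacement, which alters linker orientation and aryl group together, is not resolved either. No supporting data bear on the reason for either step.

Among the compounds shown, linker orientation and aryl group change together between compound 2 and compound 3, so the contribution of each remains open. Also open, as far as these compounds go, is whether an aminomethyl or carboxylic acid group on the aryl ring of the compound 3 linker would move the number beyond the scatter.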